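Heptylamino in Place of Chloro: Cytotoxicity Outlook

The compounds below may be only part of what the source reports. "The series", "measured", "known", "first", "only" and "open" are said of these compounds alone.

Compound 1 `O=C(NCc1ccccc1)c1cncc(Cl)n1` is the starting point of this account. In an ADME assay on HeLa cells (Homo sapiens) for cytotoxicity, read by microscopy, with a stated time of 6 days (on this read-out higher numbers stand for lower toxicity in this test and lower numbers for higher toxicity in this test), compound 1 gives "not determined" (no result reported), so no number for compound 1 exists there. For the measured compounds named here, the only reading of this kind belongs to a related amide, compound 2 `CCCCCCCNc1nccnc1C(=O)NCc1ccccc1`, which carries the heptylamino group on another ring carbon. In this assay compound 2 gives > 100000 nM, a limit of the assay rather than a measured number. The anchor for what follows is thus (the limit of > 100000 nM in this assay, at which 1 of the 2 values shown sits). The change under study is heptylamino in place of chloro on an aromatic carbon, which produces compound 3 `CCCCCCCNc1cncc(C(=O)NCc2ccccc2)n1`. Going by the values given here, with no measured step to lean on, the step in this assay from compound 1 to compound 3 is expected to be small, none beyond the scatter, with no sign of added toxicity, guided by the limit of > 100000 nM in this assay, at which 1 of the 2 values shown sits. Compound 3 is therefore expected to show 100000 nM, with a range of 30000 nM to 300000 nM.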

Compound 3, minimum cytotoxic concentration: > 100000 nM
Compound 3: a limit, no number; the forecaster's own chance of this, stated with the estimate: 75%; the middle value sits exactly at the limit.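

In this assay compound 3 gives > 100000 nM, a limit of the assay and not a number. For the compounds shown here, no step from compound 1 to compound 3 can be read from this result. The compounds shown leave open how heptylamino in place of chloro affects toxicity to these cells.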